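Hydroxyphenyl Swap on a Pyridine Core: Topoisomerase 1 Inhibition

The compounds below may be only part of what the source reports. "The series", "measured", "known", "first", "only" and "open" are said of these compounds alone.

Compound 1 `Oc1ccc(-c2cc(-c3cccc(O)c3)nc(-c3ccccc3O)c2)cc1`: in an assay on isolated protein for inhibition of DNA topoisomerase 1 (Homo sapiens), with a stated time of 30 min, tested at 100 uM (on this read-out lower numbers stand for less inhibition and higher numbers for more inhibition at the one concentration tested (going by the name of the read-out)), compound 1 gives 1.5%
Compound 2 `Oc1ccc(-c2cc(-c3cccc(O)c3)nc(-c3cccc(O)c3)c2)cc1`: in this assay compound 2 gives 0%
Compound 3 `Oc1ccc(-c2cc(-c3ccccc3O)cc(-c3ccc(O)cc3)n2)cc1`: in this assay compound 3 gives 0.4%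

All three numbers lie close together. Compound 2 gives a value that compound 3 sits within the scatter of, and compound 1 likewise sits within the scatter of compound 2, so none of the three can be set apart from the others in this assay.

Compound 4 `Oc1cccc(-c2cc(-c3cccc(O)c3)nc(-c3cccc(O)c3)c2)c1` has not yet been measured. It differs from compound 2 in one place: 3-hydroxyphenyl in place of 4-hydroxyphenyl on an aromatic carbon. Among the measured compounds shown here, the one measured step that bears on this kind of change is a number 1.5 percentage points lower from compound 1 to compound 2 (within the scatter), a different swap of one hydroxyphenyl for another on the shared core that left the read-out unchanged within the scatter. Compounds 2 and 3, which differ in how their hydroxyphenyl groups are arranged, likewise show two values that lie within the scatter of each other. There is therefore no basis for expecting a step beyond the scatter in this assay in either direction.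

Compound 4 is expected to give about 1%, with a range from 0% to 8%, which amounts to an expected step of a number 1 percentage points higher from compound 2 to compound 4 (within the scatter).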

Compound 4, a percentage reported as inhibition, at one concentration (the size of the read-out at that concentration, not a potency): 0%
Beside the measured number, compound 4's estimate is 1 percentage points above it; measured number inside the range.
By their numbers in this assay, from the lowest: compounds 2, 4, 3 and 1 (each within the scatter of the next).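

In this assay, placing 3-hydroxyphenyl in place of 4-hydroxyphenyl on the aromatic carbon opposite the ring nitrogen gives no change at the digits printed from compound 2 to compound 4 (within the scatter). This puts a direct test on this position, meta to two 3-hydroxyphenyl groups, and adds a second hydroxyphenyl swap to the earlier one on another aromatic carbon, which gave a number 1.5 percentage points lower from compound 1 to compound 2 (within the scatter); with compound 4, a form of the shared core bearing only 3-hydroxyphenyl groups also stands within the scatter of compound 2. No measurement shown offers an explanation for this result.

The compounds shown carry only hydroxyphenyl groups on the shared core, leaving open what an amine, a carboxylic acid or a longer chain on the aromatic carbon opposite the ring nitrogen would give in this assay. Also open, from the compounds shown here alone, is whether the swap between 3-hydroxyphenyl and 4-hydroxyphenyl would separate compound 2 and compound 4 at any other concentration, since the read-out here comes from a single one.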